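One Added Chain on a Weak Inhibitor

This account rests on a few compounds, and the source may have more. Where it says the series, first, only, none or still open, it means among the compounds named here.

In a functional assay on SK-MEL-28 cells (Homo sapiens) for inhibition, read by colorimetric assay and MTT assay, with a stated time of 72 h (a higher number here means a weaker inhibitor, a lower number a stronger inhibitor), compound 2 `COc1ccccc1-c1cnc(OC)n1C` gives only a limit, > 100000 nM, and no number. Compound 1 `C=CCCCCOc1ccccc1-c1cnc(OCCCCC=C)n1C` reads 5000 nM in this assay. Compound 3 `C=CCCCCOc1ccccc1-c1cnc(OC)n1C` departs from compound 2 by pent-4-en-1-yl in place of hydrogen on a saturated chain carbon bound to an oxygen on an aromatic ring, turning methoxy into (hex-5-en-1-yl)oxy. Some gain is expected, with compound 1 at 5000 nM as the only numeric guide. The expected change is an at least 3.3-fold lower number from compound 2 to compound 3 (0.52 log units; beyond the scatter), toward stronger inhibition. For compound 3 the estimated value is 30000 nM, within an expected range of 10000 nM to 90000 nM.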

Compound 3, half-maximal inhibitory concentration: 85000 nM
Compound 3: the middle estimate sits 2.8-fold (0.45 log units) below what was measured; low and high end bracket the measured number.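

With one (hex-5-en-1-yl)oxy group in place of methoxy, the change gives an at least 1.1-fold lower number from compound 2 to compound 3 (0.07 log units; that floor lies within the scatter), so this chain alone cannot be shown to matter. That floor rests on a limit for compound 2, not a number: the limit of > 100000 nM in this assay, at which 1 of the 3 values shown sits. The second chain counts for far more, since losing pent-4-en-1-yl from the other oxygen gives a 17-fold higher number from compound 1 to compound 3 (1.23 log units; beyond the scatter). The compounds shown leave open whether that second chain alone would suffice. They also leave open whether the double bond matters, which a saturated hexyl chain would test.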